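The compounds below may be only part of what the source reports. "The series", "measured", "known", "first", "only" and "open" are said of these compounds alone.

So far, only two compounds have numbers in a functional assay on Cortical neurone cells (Mus musculus, strain C57BL/6), read by FLIPR and calcium flux, with a stated time of 8 min; on this read-out higher numbers stand for weaker inhibition and lower numbers for stronger inhibition. Compound 2 `O=c1cc(-c2ccccc2)[nH]c2nc(Cc3ccccc3)nn12` gives 1310 nM, the lower of the two numbers and therefore the stronger inhibition. Compound 1 `Cc1ccc(Cc2nc3[nH]c(-c4ccc(Cl)cc4)cc(=O)n3n2)cc1`, which also carries a 4-methylbenzyl group, gives 5440 nM, and the gap between these two values lies beyond the scatter of repeated measurements.

The next compound to consider is compound 3 `Cc1ccc(Cc2nc3[nH]c(-c4ccccc4)cc(=O)n3n2)cc1`, which comes from compound 2 through one small edit: methyl in place of hydrogen on an aromatic carbon. In words, this is methyl in place of hydrogen on an aromatic carbon, turning benzyl into 4-methylbenzyl. Within the data shown here, no pair of measured compounds isolates this change, so its effect in this assay has no direct precedent.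

Among the measured compounds shown here, the only hint is compound 1 at 5440 nM, the sole measured compound bearing the 4-methylbenzyl group. A small rise in the number, meaning somewhat weaker inhibition, is therefore expected, and it may not clear the scatter. The estimated change is a 1.5-fold higher number from compound 2 to compound 3 (0.18 log units; within the scatter). The estimated value for compound 3 is 2000 nM, within an expected range of 800 nM to 5500 nM.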

Compound 3, half-maximal inhibitory concentration: 1150 nM
Estimate against measurement, compound 3: 1.7-fold (0.24 log units) above; measured number inside the range.
By their numbers in this assay, from the lowest: compounds 3 and 2 (each within the scatter of the next); then compound 1.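

In this assay, methyl in place of hydrogen on the benzyl group leaves the number unchanged within the scatter, with a 1.1-fold lower number from compound 2 to compound 3 (0.06 log units; within the scatter) as the step, so turning benzyl into 4-methylbenzyl shows no measurable effect on inhibition here. Among these compounds, the second comparison gives the first clean reading of chloro, since compound 1 and compound 3 both carry 4-methylbenzyl and differ only in hydrogen in place of chloro on an aromatic carbon: the change gives a 4.7-fold lower number from compound 1 to compound 3 (0.67 log units; beyond the scatter) and so goes with stronger inhibition, a modest but real step. No measurement available here explains either result.

On these data alone, these readings rest on one pair each, so it remains unknown whether the methyl result holds for other groups at that spot, such as methoxy, an amine or a carboxylic acid, or for a longer chain in place of methyl. As far as these compounds go, it is equally open whether the loss seen with chloro extends to fluoro or bromo, and whether chloro would have the same effect on compound 2, which has the plain benzyl group.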